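Benzylamine Sulfonamides Against a Pancreatic Cancer Cell Line

A few compounds are considered here, and "the series" means these few. Any claim that something is new, unique, unknown or untested is made for them only; others in the source may bear on it.

Compound 1, `O=S(=O)(NCCCNCc1ccc(Cl)c(Cl)c1)c1cc(C(F)(F)F)cc(C(F)(F)F)c1`, gives 2700 nM in a functional assay on MIA PaCa-2 cells (Homo sapiens) for inhibition, read by MTT assay, with a stated time of 72 h; on this read-out higher numbers stand for weaker inhibition of growth and lower numbers for stronger inhibition of growth.
Compound 2, `CC(C)(C)c1ccc(CNCCNS(=O)(=O)c2cc(C(F)(F)F)cc(C(F)(F)F)c2)cc1`, gives 15000 nM in this assay.

Of the two compounds with numbers in this assay, compound 1 holds the lowest, and the gap to compound 2 lies beyond the scatter of repeated measurements. For the measured compounds named here, compound 2 differs from compound 1 in both the chain and the aryl group, so the two numbers show only that compound 1 is the stronger inhibitor of growth of the pair.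

Compound 3, `COc1ccccc1CNCCCNS(=O)(=O)c1cc(C(F)(F)F)cc(C(F)(F)F)c1`, has not yet been measured in this assay. It keeps the shared core and the chain of compound 1 and differs only in the aryl group: 2-methoxyphenyl in place of 3,4-dichlorophenyl on a saturated chain carbon bound to an amine nitrogen. Going by the values given here, no single-change step between measured compounds is available to anchor the effect of this exchange. Among the compounds with values here, the one measured comparison, compound 1 against compound 2, shows that altering the aryl group together with the chain raised the number considerably. On that basis the step of a 2.6-fold higher number from compound 1 to compound 3 (0.41 log units; beyond the scatter) is expected to be a moderate rise, beyond the scatter, toward weaker inhibition of growth. Compound 3 is therefore estimated at 7000 nM, within a range from 2500 nM to 20000 nM.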

Compound 3, concentration for 50% growth inhibition: 3100 nM
The estimate for compound 3 lay 2.3-fold (0.35 log units) above the measured number; the range from low to high includes it.
By their numbers in this assay, from the lowest: compounds 1 and 3 (each within the scatter of the next); then compound 2.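

In this assay, the exchange of 3,4-dichlorophenyl for 2-methoxyphenyl on a saturated chain carbon bound to an amine nitrogen gives a 1.1-fold higher number from compound 1 to compound 3 (0.06 log units; within the scatter), so with the chain of compound 1 held fixed, the two aryl groups cannot be told apart by their numbers. For the compounds shown here, this is the first single-change step, and it shows that this position accepts the loss of both chlorine atoms and the arrival of a methoxy group, with its one hydrogen-bond acceptor, without a shift beyond the scatter. Nothing at hand accounts for this match between the two groups.

The compounds shown leave open whether the same match holds for other groups at this position, such as an unsubstituted phenyl or a phenyl carrying a nitrile, since one exchange says nothing about the range of aryl groups accepted there. They also leave open what the chain contributes on its own, as no pair shown changes the chain alone, and a longer chain bearing 3,4-dichlorophenyl would be needed to separate that effect.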